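Swapping Dichlorophenyl for Dimethoxyphenyl: Expected Half-life

A few compounds are considered here, and "the series" means these few. Any claim that something is new, unique, unknown or untested is made for them only; others in the source may bear on it.

Within the data shown here, compound 1 `Cc1oc(-c2ccc(Cl)c(Cl)c2)nc1CN1CCC(C(=O)NCCCN2C[C@H](C)C[C@H](C)C2)CC1` is one of three compounds measured in an ADME assay on microsomes from liver (Rattus norvegicus) for metabolic stability, read by LC-MS, using NADPH, at 37 degrees C; a higher number here means that the compound lasts longer, a lower number that the compound disappears faster. Compound 1 gives > 0.5 h, which is a limit of the assay rather than a number, so its exact standing is open (the limit of > 0.5 h in this assay, at which 1 of the 3 values shown sits). Compound 2 `Cc1cccc(Cl)c1-c1nc(CN2CCC(C(=O)NCCCN3CCC(C)(C)CC3)CC2)c(C)o1` gives 0.0733 h, and compound 3 `Cc1cccc(Cl)c1-c1nc(CN2CCC(C(=O)NCCCN3CCC(C(C)C)CC3)CC2)c(C)o1` gives 0.0333 h. Among the measured compounds shown here, the single measured step, a 2.2-fold lower number from compound 2 to compound 3 (0.34 log units; beyond the scatter), alters the saturated ring at the end of the chain, not the aromatic ring changed here. Compound 4 `COc1ccc(-c2nc(CN3CCC(C(=O)NCCCN4C[C@H](C)C[C@H](C)C4)CC3)c(C)o2)cc1OC` differs from compound 1 by 3,4-dimethoxyphenyl in place of 3,4-dichlorophenyl on an aromatic carbon. For the measured compounds named here, no measured step touches this ring, so the size and direction of the change are unknown, and only a modest shift is assumed. Compound 4 is therefore expected to give 0.4 h, between 0.12 h and 1.5 h, an expected step of an at least 1.2-fold lower number from compound 1 to compound 4 (0.09 log units; that floor lies within the scatter).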

Compound 4, half-life: > 0.5 h
Compound 4 ended at the assay's limit; the forecaster's own chance of this, stated with the estimate: 40%; middle value at least 1.2-fold (0.09 log units) away from the limit.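

Compound 1 and compound 4 both end at the same limit, so no step between them can be read: the limit of > 0.5 h in this assay, at which 2 of the 4 values shown sit.

The compounds shown leave open how long either lasts in this assay, and whether 3,4-dimethoxyphenyl in place of 3,4-dichlorophenyl shifts that at all.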